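This account rests on a few compounds, and the source may have more. Where it says the series, first, only, none or still open, it means among the compounds named here.

The series sets three measured compounds against one that is still unmeasured. Compound 1 `CCOC(=O)C(=Cc1c(-c2ccccc2)[nH]c2ccccc12)C(=O)OCC` carries two ester groups on the double bond; compound 2 `COc1ccc(-c2[nH]c3ccc(OC)cc3c2/C=C(\C#N)S(=O)(=O)c2ccccc2)cc1` and compound 3 `CC(=O)/C(=C\c1c(-c2ccccc2)[nH]c2ccccc12)S(=O)(=O)c1ccccc1` each carry a phenylsulfonyl there, joined to a nitrile in compound 2 and to an acetyl in compound 3. In a functional assay on UACC-62 cells (Homo sapiens) for inhibition, read by sulforhodamine B assay, with a stated time of 48 h (on this read-out lower numbers stand for stronger inhibition of growth and higher numbers for weaker inhibition of growth), compound 1 gives 4600 nM, compound 2 gives 660 nM and compound 3 gives 1000 nM. Compound 3 thus stands with a number that lies within the scatter of that of compound 2, while compound 1 shows a number higher than that of compound 3 by a margin beyond the scatter.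

Compound 4 `O=C(/C(=C\c1c(-c2ccccc2)[nH]c2ccccc12)S(=O)(=O)c1ccccc1)c1ccccc1` differs from compound 3 in one place: phenyl in place of methyl on a carbonyl carbon. Going by the values given here, no pair of measured compounds in this assay isolates such a change, so the expectation rests only on the three numbers above. He expects the step from compound 3 to compound 4 to be small, a 1.3-fold lower number from compound 3 to compound 4 (0.10 log units; within the scatter), most likely none beyond the scatter, with no clear lean in either direction. For compound 4 he therefore estimates a value of 800 nM in this assay, with a range from 300 nM to 2500 nM.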

Compound 4, concentration for 50% growth inhibition: 9000 nM
Compound 4: the middle estimate sits 11-fold (1.05 log units) below what was measured; the whole stated range lies below it.
By their numbers in this assay, from the lowest: compounds 2 and 3 (each within the scatter of the next); then compounds 1 and 4 (each within the scatter of the next).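

In this assay, going by these compounds alone, the change from acetyl to benzoyl gives a 9.0-fold higher number from compound 3 to compound 4 (0.95 log units; beyond the scatter), and this is the first step that isolates a single change on the carbonyl carbon. Within the data shown here, it shows that this place is not indifferent to what it carries: the earlier compounds differ in more than one place and could not show this, whereas here phenyl, with 6 heavy atoms and an aromatic ring, replaces methyl and growth inhibition clearly weakens while the rest of the molecule stays the same. Nothing measured here explains why this step is as large as it is, and the result stands as an observation on one pair of compounds.

From the compounds shown here alone, with only methyl and phenyl seen at this place, it remains open whether an ethyl group or a longer chain would keep the level of the acetyl compound or follow the benzoyl compound, and whether a saturated cyclohexyl ring would behave like phenyl. Also open, going by these compounds, is what a methoxy group or an amine on the entering phenyl would do to the loss seen here.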